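The source may hold more compounds than are shown below. What is called first, only, known or untested is meant among the compounds shown, and "the series" means these compounds.

In an ADME assay on HEK293 cells (Homo sapiens) for cytotoxicity, read by MTT assay, with a stated time of 24 h (on this read-out lower numbers stand for stronger inhibition and higher numbers for weaker inhibition), compound 1 `O=[N+]([O-])c1ccc2nc(NCc3ccc(C(F)(F)F)cc3)c(N3CCCCC3)nc2c1` gives > 200 ug/mL, which is a limit of the assay and not a number. Within the data shown here, compound 2 `Cc1ccc(CNc2nc3ccc([N+](=O)[O-])cc3nc2NCCCN(C)C)cc1` gives 15.8 ug/mL, the only actual number available so far, so it cannot yet be ranked precisely against another measured compound. Compound 3 `CN(C)CCCNc1nc2cc([N+](=O)[O-])ccc2nc1NCc1cccc(Br)c1` differs from compound 2 in one place, with 3-bromophenyl in place of 4-methylphenyl on a saturated chain carbon bound to a nitrogen on an aromatic ring. Among the measured compounds shown here, no measured pair shows what a swap of this kind does in this assay. For the measured compounds named here, with compound 2 at 15.8 ug/mL as the only guide, no change beyond the usual scatter is expected, and neither direction is favoured. The expected move a 1.1-fold lower number from compound 2 to compound 3 (0.02 log units; within the scatter) is therefore small. For compound 3 the estimate is 15 ug/mL, with an expected range of 5 ug/mL to 45 ug/mL.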

Compound 3, half-maximal inhibitory concentration: 3.66 ug/mL
Beside the measured number, compound 3's estimate is 4.1-fold (0.61 log units) above it; the whole stated range lies above it.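

In this assay, 3-bromobenzyl in place of 4-methylbenzyl brings a 4.3-fold lower number from compound 2 to compound 3 (0.64 log units; beyond the scatter). Among these compounds, this is the first measured pair in the set, and it shows that the group at this place, on a saturated chain carbon bound to a nitrogen on an aromatic ring, can shift the read-out on its own while the rest of the molecule stays the same. The step is modest and runs towards stronger inhibition, and nothing measured here explains it.

The swap replaces methyl with bromine and also moves the group on the ring, so this single pair cannot separate the two changes. A 4-bromophenyl or 3-methylphenyl group at this place would show which change carries the step, and an unsubstituted phenyl would show how either compares with no added group at all.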